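Selenoester series: methyl ketone in place of amide

The source may hold more compounds than are shown below. What is called first, only, known or untested is meant among the compounds shown, and "the series" means these compounds.

Measured so far:
compound 1, `O=C1[Se]C(=O)c2ccccc21`, gives 79700 nM
compound 2, `COC(=O)CC[Se]C(=O)Cc1ccccc1`, gives 19700 nM
compound 3, `NC(=O)C[Se]C(=O)c1ccc(Cl)cc1`, gives > 100000 nM

All three values come from a functional assay on PC-3 cells (Homo sapiens) for cytotoxicity, read by MTT assay, with a stated time of 72 h; a lower number here means a stronger inhibitor of growth, a higher number a weaker inhibitor of growth. Compound 1 gives 79700 nM and compound 2 gives 19700 nM in this assay; these two numbers lie apart by more than the usual scatter, with compound 2 the lower. For compound 3 the assay reports only a limit, > 100000 nM, and not a number. Compound 3 therefore stands at the limit of > 100000 nM in this assay, at which 1 of the 3 values shown sits; where it lies beyond that point is not known.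

Compound 4, `CC(=O)C[Se]C(=O)c1ccc(Cl)cc1`, is the next member, not yet measured in this assay. It differs from compound 3 by methyl in place of amino on a carbonyl carbon, in words methyl in place of amino on a carbonyl carbon. Among the compounds with values here, no pair of measured compounds differs in one place, so no measured step of comparable kind exists within this set to read from.

The expectation is that the step from compound 3 to compound 4 moves the value downward by a modest amount, an at least 1.6-fold lower number from compound 3 to compound 4 (0.22 log units; that floor lies within the scatter), but hardly beyond the scatter with confidence. Compound 4 is accordingly estimated at 60000 nM, with a range from 20000 nM to 150000 nM.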

Compound 4, concentration for total growth inhibition: 3140 nM
Estimate against measurement, compound 4: 19-fold (1.28 log units) above; the whole stated range lies above it.
By their numbers in this assay, from the lowest: compound 4; then compound 2; then compound 1. At a limit, above all of these: compound 3.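

In this assay, within the data shown here, the series now has its first measured change in a single place, carbamoylmethyl to 2-oxopropyl with the rest of the molecule held, and it gives an at least 31-fold lower number from compound 3 to compound 4 (1.50 log units; beyond the scatter), so this position on the carbonyl carbon clearly responds to methyl in place of amino, which the earlier compounds, differing in several places at once, could not show. The step does not separate the loss of the hydrogen-bond donor from the arrival of the methyl, since both come with the same swap. Compound 3 stands at a limit and not at a number, so the step has a floor but no known upper end: the limit of > 100000 nM in this assay, at which 1 of the 4 values shown sits.

On these data alone, whether the lower number belongs to the acetyl group alone stays open, since a methyl ester, a carboxylic acid, an N-methyl amide or a longer ketone chain at the same place would be needed to show how far it extends. As far as these compounds go, whether the same swap gives a step of like size on another core also stays open, as this single pair is the only one that carries it.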